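Substituent on the ring amine nitrogen: next step

The source may hold more compounds than are shown below. What is called first, only, known or untested is meant among the compounds shown, and "the series" means these compounds.

Compound 1 `Cc1cccc2sc(NC(=O)CCN3CCN(C4CCN(C)CC4)CC3)nc12` gives 6000 nM in an assay on membranes from brain for displacement of a labelled ligand from Sigma non-opioid intracellular receptor 1 (Cavia porcellus), read by scintillation counting, with a stated time of 120 min; on this read-out higher numbers stand for weaker inhibition and lower numbers for stronger inhibition. Going by the values given here, compound 2 `Cc1cccc2sc(NC(=O)CCN3CCN(CCN(C(C)C)C(C)C)CC3)nc12` gives 809 nM in this assay, the lowest of the two numbers; the only step to it is a 7.4-fold lower number from compound 1 to compound 2 (0.87 log units; beyond the scatter). Compound 3 `Cc1ccccc1N1CCN(CCC(=O)Nc2nc3c(C)cccc3s2)CC1` carries the change (2-methylphenyl in place of 2-(diisopropylamino)ethyl on an amine nitrogen in a ring). Among the compounds with values here, one measured step bears on exchanges at this nitrogen, a 7.4-fold lower number from compound 1 to compound 2 (0.87 log units; beyond the scatter), but its entering group differs from the present one, so the size in this assay is uncertain; a step of that order or smaller, toward a lower number, is expected. Compound 3 is expected at 400 nM (range 80 nM to 2000 nM), an expected step of a 2.0-fold lower number from compound 2 to compound 3 (0.31 log units; beyond the scatter).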

Compound 3, inhibition constant: 1000 nM
The estimate for compound 3 lay 2.5-fold (0.40 log units) below the measured number; the measured number falls inside the stated range.
By their numbers in this assay, from the lowest: compounds 2 and 3 (each within the scatter of the next); then compound 1.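

In this assay, the ring nitrogen tolerates an aromatic group as well as an amine-bearing chain: 2-methylphenyl and 2-(diisopropylamino)ethyl give matching numbers (a 1.2-fold higher number from compound 2 to compound 3 (0.09 log units; within the scatter)). The second nitrogen of 2-(diisopropylamino)ethyl is therefore not needed to reach this level, and 2-methylphenyl also retains the gain over 1-methylpiperidin-4-yl (a 6.0-fold lower number from compound 1 to compound 3 (0.78 log units; beyond the scatter)). No supporting data bear on why these groups match.

Open, on these data alone, is whether plain phenyl or a pyridine ring would match 2-methylphenyl. Also open, as far as these compounds go, is whether a benzyl group, with a carbon spacer before the aromatic ring, would move the number beyond the scatter.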